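Aryl versus methyl on the sulfonamide of the pyridine

The source may hold more compounds than are shown below. What is called first, only, known or untested is meant among the compounds shown, and "the series" means these compounds.

Measured so far in a functional assay on SNU-638 cells (Homo sapiens) for antiproliferative activity, read by sulforhodamine B assay, with a stated time of 72 h; on this read-out lower numbers stand for stronger inhibition and higher numbers for weaker inhibition:
compound 1 `CCOC(=O)c1cnc2ccc(-c3cnc(OC)c(NS(C)(=O)=O)c3)cn12`: 90 nM
compound 2 `COc1ncc(-c2ccc3ncc(C(=O)NCc4ccncc4)n3c2)cc1NS(=O)(=O)c1ccc(F)cc1F`: 490 nM
compound 3 `CCOC(=O)c1cn2cc(-c3cnc(OC)c(NS(=O)(=O)c4ccc(F)cc4)c3)ccc2n1`: > 20000 nM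

Compound 1 gives the lowest of the two numbers in this assay, and the gap to compound 2 lies beyond the scatter. For compound 3, which also carries a (4-fluorophenyl)sulfonyl group, the assay reports only a limit, not a number. Compound 4 `CCOC(=O)c1cnc2ccc(-c3cnc(OC)c(NS(=O)(=O)c4ccc(F)cc4)c3)cn12` is not yet measured; it keeps the core of compound 1 and changes one group: 4-fluorophenyl in place of methyl on a sulfonyl sulfur. The step is expected to weaken inhibition well beyond the scatter, given that compound 2, the other aryl sulfonamide with a number, gives 490 nM. The expected step is a 17-fold higher number from compound 1 to compound 4 (1.22 log units; beyond the scatter). Compound 4 is thus estimated at 1500 nM, with a range from 300 nM to 10000 nM.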

Compound 4, half-maximal inhibitory concentration: > 20000 nM
Compound 4: only a limit was reported; the forecaster's own chance of this, stated with the estimate: 25%; middle value at least 13-fold (1.12 log units) from the limit.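

Compound 4 gives only a limit in this assay, > 20000 nM. Among the compounds shown here, this is the first reading of the position with a single change: on the core of compound 1, 4-fluorophenyl in place of methyl on a sulfonyl sulfur gives an at least 220-fold higher number from compound 1 to compound 4 (2.34 log units; beyond the scatter), so this aryl group does not keep the inhibition seen with methyl. The full size of the step stays unknown, as the reading ends at an assay limit: the limit of > 20000 nM in this assay, at which 2 of the 4 values shown sit.

Open, on these data alone, is whether ethyl or unsubstituted phenyl on the sulfonyl sulfur would retain inhibition on this core. The compounds shown also do not separate the contribution of the fluorine from that of the ring.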